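This account rests on a few compounds, and the source may have more. Where it says the series, first, only, none or still open, it means among the compounds named here.

Working notes on the series.

Of the compounds shown here, three share one core and have been measured in a functional assay on EKVX cells (Homo sapiens) for inhibition, read by sulforhodamine B assay, with a stated time of 48 h, tested at 10 uM; a lower number here means less inhibition, a higher number more inhibition at the concentration tested (going by the name of the read-out). Compound 1, `COc1ccc(-c2cn3ccnc3c(-c3ccc4ncn(C5CCCCC5)c4c3)n2)cc1`, gives 56.7%. Among the measured compounds shown here, compound 2, `Fc1ccccc1-c1cn2ccnc2c(-c2ccc3ncn(C4CCCCC4)c3c2)n1`, gives 16%, and the single-point change between them, a number 40.7 percentage points lower from compound 1 to compound 2 (beyond the scatter), is the only measured step in the set. Compound 3, `CCc1ccc(-c2cn3ccnc3c(-c3ccc4ncn(Cc5ccccc5)c4c3)n2)cc1`, gives 39.7%; it stands second highest of the three numbers, with compound 1 above it beyond the scatter and compound 2 below it beyond the scatter.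

The next compound, compound 4, `O=Cc1ccc(-c2cn3ccnc3c(-c3ccc4ncn(Cc5ccccc5)c4c3)n2)cc1`, differs from compound 3 in one place: formyl in place of ethyl on an aromatic carbon, on an aromatic carbon of a six-membered aromatic ring of carbon only, para to a large group. The step from compound 1 to compound 2 also alters the aryl group at this position and bears on the present change only in showing that such edits can move this assay by a large amount; it involves different groups and a different position on that ring, so it gives no direction for formyl in place of ethyl. For the measured compounds named here, with one acceptor entering and no measured precedent for it, the estimated step of a number 0.3 percentage points higher from compound 3 to compound 4 (within the scatter) is set near zero, within the scatter, with wide bounds. Compound 4 is expected to give about 40%, between 15% and 65%.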

Compound 4, a percentage reported as inhibition, at one concentration (the size of the read-out at that concentration, not a potency): 20.9%
Compound 4: middle estimate off by 19.1 percentage points, on the high side; low and high end bracket the measured number.
By their numbers in this assay, from the lowest: compounds 2 and 4 (each within the scatter of the next); then compound 3; then compound 1.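

In this assay, the change from 4-ethylphenyl to 4-formylphenyl gives a number 18.8 percentage points lower from compound 3 to compound 4 (beyond the scatter), so this position responds to a substitution on the same ring with the rest of the structure unchanged. Ethyl and formyl each count 2 heavy atoms, which shows that the number can move beyond the scatter with no change in that count, while a carbonyl and a hydrogen-bond acceptor enter in place of the two carbons. No measured property of these groups is available to account for the step.

On these data alone, it remains open whether the lower number follows from the formyl group itself or from the loss of ethyl, a question that a carboxylic acid, a hydroxymethyl group, an amine or a longer chain at this place would help to separate. Among the compounds shown here, it also remains open whether formyl in place of ethyl gives a step of similar direction and size when the other substituent on the shared core is the one carried by compound 1.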